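Two More Carbons on the Ester Chain

The source may hold more compounds than are shown below. What is called first, only, known or untested is meant among the compounds shown, and "the series" means these compounds.

Compound 1 `CCCCCCCCCOC(=O)CCC(=O)N1CCN(CCCOc2cc3c(Nc4ccc(F)c(Cl)c4)ncnc3cc2OC)CC1` and compound 2 `CCCCCCCCCCCOC(=O)CCC(=O)N1CCN(CCCOc2cc3c(Nc4ccc(F)c(Cl)c4)ncnc3cc2OC)CC1` share one core and differ only in the length of a saturated chain. In a functional assay on A549 cells (Homo sapiens) for cytotoxicity, read by MTT assay, with a stated time of 24 h, tested at 40 uM (a higher number here means a weaker effect of the compound at the concentration tested, a lower number a stronger effect), compound 1 gives 17.9%, and compound 2 gives 12%. The step of a number 5.9 percentage points lower from compound 1 to compound 2 (within the scatter) lies within the scatter. Compound 2 holds the lowest of the two numbers, with compound 1 nearest. Compound 3 `CCCCCCCCCCCCCOC(=O)CCC(=O)N1CCN(CCCOc2cc3c(Nc4ccc(F)c(Cl)c4)ncnc3cc2OC)CC1` carries the same kind of change once more: ethyl in place of hydrogen on a saturated chain carbon, ten or more bonds along the chain from an oxygen next to a carbonyl group. For the measured compounds named here, the only measured step bearing on this was within the scatter, so no step beyond the scatter is expected in this assay; the estimated step is a number 1 percentage points lower from compound 2 to compound 3 (within the scatter). Compound 3 is therefore expected to give 11%, within a range from 2% to 22%.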

Compound 3, a percentage reported as activity, at one concentration (the size of the read-out at that concentration, not a potency): 71.1%
Compound 3: middle estimate off by 60.1 percentage points, on the low side; the measured number lies above the stated range.
By their numbers in this assay, from the lowest: compounds 2 and 1 (each within the scatter of the next); then compound 3.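

In this assay, lengthening this saturated chain does not stay without consequence: the same ethyl in place of hydrogen gives a number 59.1 percentage points higher from compound 2 to compound 3 (beyond the scatter) and so marks a sharp break rather than a gradual drift. The butyl change gives a number 53.2 percentage points higher from compound 1 to compound 3 (beyond the scatter) and confirms that the longest of the three chains has by far the weakest effect at the concentration tested. Nothing measured here explains this sudden loss.

As far as these compounds go, whether a longer chain stays equally weak remains open. So does whether an amine or a carboxylic acid at the chain end would restore the stronger effect.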